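Branching the chain on compound 1's double-bonded nitrogen

The source may report more compounds than this note shows. Statements on the series, on what has been measured and on what is new or still open speak of the compounds shown alone.

Three compounds share one core and differ only in the chain on a double-bonded nitrogen. In a functional assay on the whole organism (blood, strain Wistar-Okamoto) with Rattus norvegicus as the target, with a stated time of 5 days (on this read-out lower numbers stand for an effect already at smaller amounts and higher numbers for an effect only at larger amounts of compound), compound 1 `CCCCC/N=C(\NC#N)Nc1cccnc1` gives 20 mg/kg, compound 2 `CC(C)/N=C(\NC#N)Nc1cccnc1` gives 2.5 mg/kg, and compound 3 `CCC(C)/N=C(\NC#N)Nc1cccnc1` gives 20 mg/kg. Compound 1 thus stands level with compound 3 at the top of these three numbers, while compound 2 needs a smaller amount: an 8.0-fold lower number from compound 1 to compound 2 (0.90 log units; beyond the scatter), whereas no change at the digits printed from compound 1 to compound 3 (within the scatter).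

Compound 4 `CCC(C)(CC)/N=C(\NC#N)Nc1cccnc1` carries a more branched chain: 1-ethyl-1-methylpropyl in place of pentyl on a double-bonded nitrogen.

Two measured steps speak to this change. Shortening the pentyl to isopropyl helped, since an 8.0-fold lower number from compound 1 to compound 2 (0.90 log units; beyond the scatter), yet reshaping it into sec-butyl did nothing, since no change at the digits printed from compound 1 to compound 3 (within the scatter). Lengthening the branched chain by one carbon went the wrong way, as an 8.0-fold higher number from compound 2 to compound 3 (0.90 log units; beyond the scatter). Compound 4 keeps a branched chain but grows it further, so no gain beyond the scatter is expected; the number may stay where compound 1 sits or drift somewhat higher.

For compound 4 in this assay the expected value is 25 mg/kg, with a range from 6 mg/kg to 100 mg/kg, which as a step from compound 1 means a 1.3-fold higher number from compound 1 to compound 4 (0.10 log units; within the scatter).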

Compound 4, minimum effective dose: 0.5 mg/kg
For compound 4 the middle estimate is 50-fold (1.70 log units) above the measured one; the measured number lies below the stated range.
By their numbers in this assay, from the lowest: compound 4; then compound 2; then compounds 1 and 3 (each within the scatter of the next).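

In this assay, within the data shown here, the chain on a double-bonded nitrogen turns out to have far more influence than the earlier compounds suggested: 1-ethyl-1-methylpropyl in place of pentyl gives the largest step in this set (a 40-fold lower number from compound 1 to compound 4 (1.60 log units; beyond the scatter)). Chain size alone does not order these numbers, since adding one carbon to the isopropyl chain made the number worse (an 8.0-fold higher number from compound 2 to compound 3 (0.90 log units; beyond the scatter)), whereas ethyl in place of hydrogen on the sec-butyl chain, at the saturated chain carbon bound to the double-bonded nitrogen, improves it sharply (a 40-fold lower number from compound 3 to compound 4 (1.60 log units; beyond the scatter)). The bigger chain also improves on the smaller isopropyl (a 5.0-fold lower number from compound 2 to compound 4 (0.70 log units; beyond the scatter)), so compound 4 has the lowest number of the four, with each of its steps to the others beyond the scatter, and compound 2 is no longer the best of the series.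

From the compounds shown here alone, it remains open whether the gain depends on the two ethyl arms of this chain or would also appear with a tert-butyl group or a cyclohexyl ring on the same nitrogen. Nothing available here explains why this chain has such a strong effect.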